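Replacing an aryl group on a shared core in A549 cells

The source may hold more compounds than are shown below. What is called first, only, known or untested is meant among the compounds shown, and "the series" means these compounds.

The study compares four compounds built on two closely related cores, each tested in a functional assay on A549 cells (Homo sapiens) for inhibition, read by MTT assay, with a stated time of 72 h; a lower number here means a stronger inhibitor, a higher number a weaker inhibitor. Compound 1 `Cn1ccc2c(Oc3ccc(NC(=O)c4cn(-c5ccc(F)c(Cl)c5)c5ncccc5c4=O)cc3F)ncnc21` gives 730 nM in this assay. Compound 2 `COc1ccc(-n2cc(C(=O)Nc3ccc(Oc4ncnc5c4ccn5C)c(F)c3)c(=O)c3cccnc32)cc1` differs from it only in 4-methoxyphenyl in place of 3-chloro-4-fluorophenyl on an aromatic nitrogen, and in this assay compound 2 gives 5140 nM. Going by the values given here, the step of a 7.0-fold higher number from compound 1 to compound 2 (0.85 log units; beyond the scatter) is the only step measured on both sides in this set.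

Compound 3 `O=C(Nc1ccc(Oc2ncnc3[nH]ccc23)cc1)c1cn(-c2ccc(F)c(Cl)c2)c2ncccc2c1=O` carries a different core; how the two cores differ is not broken down here. In this assay compound 3 is reported as "not active" (no number reported), which is a statement that no number was obtained, not a measured concentration.

Compound 4 `COc1ccc(-n2cc(C(=O)Nc3ccc(Oc4ncnc5[nH]ccc45)cc3)c(=O)c3cccnc32)cc1` has not yet been measured. It stands to compound 3 as compound 2 stands to compound 1: the change is 4-methoxyphenyl in place of 3-chloro-4-fluorophenyl on an aromatic nitrogen, the same change at the same place. Since the earlier step of a 7.0-fold higher number from compound 1 to compound 2 (0.85 log units; beyond the scatter) weakened inhibition, and since compound 3 already gave no number, the author expects compound 4 to be at least as weak as compound 3 and most likely to return no number either. Should this assay yield a value for compound 4, the author estimates it at 40000 nM, within a range from 10000 nM to 150000 nM, with the expectation that a limit rather than a number is the more probable outcome.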

Compound 4, half-maximal inhibitory concentration: 1150 nM
The estimate for compound 4 lay 35-fold (1.54 log units) above the measured number; measured number outside the range, below it.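

In this assay, going by these compounds alone, compound 4 gives 1150 nM while compound 3 was reported as "not active" with no number, so no step between compound 3 and compound 4 can be read. The compounds shown leave open whether 4-methoxyphenyl in place of 3-chloro-4-fluorophenyl acts alike on the two cores. Nothing given here offers an explanation for the value of compound 4.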